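Ester chain extension in a cytotoxicity series

The compounds below may be only part of what the source reports. "The series", "measured", "known", "first", "only" and "open" are said of these compounds alone.

Measured compounds:
compound 1 `CCCCOC(=O)CCC(=O)N1CCN(CCCOc2cc3c(Nc4ccc(F)c(Cl)c4)ncnc3cc2OC)CC1` 79.1%
compound 2 `CCCCCCCCCOC(=O)CCC(=O)N1CCN(CCCOc2cc3c(Nc4ccc(F)c(Cl)c4)ncnc3cc2OC)CC1` 17.9%

In a functional assay on A549 cells (Homo sapiens) for cytotoxicity, read by MTT assay, with a stated time of 24 h, tested at 40 uM (on this read-out higher numbers stand for a weaker effect at the one concentration tested and lower numbers for a stronger effect), compound 2 gives the lowest of the two numbers, with compound 1 the nearest at 79.1%. Compound 3 `CCCCCCCCCCCCCCOC(=O)CCC(=O)N1CCN(CCCOc2cc3c(Nc4ccc(F)c(Cl)c4)ncnc3cc2OC)CC1` differs from compound 2 by pentyl in place of hydrogen on a saturated chain carbon, nine bonds along the chain from an oxygen next to a carbonyl group. Among the compounds with values here, the only step that bears on this change is a number 61.2 percentage points lower from compound 1 to compound 2 (beyond the scatter), where the same group entered further in along the chain. Since compound 2 already stands at 17.9%, little room remains below it, so only a modest further fall, if any, is expected in this assay. Compound 3 is therefore estimated at 12% (range 3% to 35%), which means an expected step of a number 5.9 percentage points lower from compound 2 to compound 3 (within the scatter).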

Compound 3, a percentage reported as activity, at one concentration (the size of the read-out at that concentration, not a potency): 88.6%
Beside the measured number, compound 3's estimate is 76.6 percentage points below it, and the stated range ends below it.
By their numbers in this assay, from the lowest: compound 2; then compounds 1 and 3 (each within the scatter of the next).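

In this assay, pentyl at this place, nine bonds along the chain from an oxygen next to a carbonyl group, does not extend the earlier fall: the change gives a number 70.7 percentage points higher from compound 2 to compound 3 (beyond the scatter), opposite in direction to a number 61.2 percentage points lower from compound 1 to compound 2 (beyond the scatter). The two outer esters show a number 9.5 percentage points higher from compound 1 to compound 3 (within the scatter), so across these compounds the read-out follows no single direction with chain length, and compound 2 alone stands apart. Nothing measured here accounts for this reversal. As far as these compounds go, what remains open is where between compound 2 and compound 3 the turn lies, for instance with an undecyl ester, and whether a chain ending in an amine or a carboxylic acid would read like compound 2.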